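Swapping the aminophenyl ketone for a dichlorophenyl

A few compounds are considered here, and "the series" means these few. Any claim that something is new, unique, unknown or untested is made for them only; others in the source may bear on it.

Of the compounds shown here, two sharing the same core have been measured in a functional assay on SK-OV-3 cells (Homo sapiens) for inhibition, read by sulforhodamine B assay, with a stated time of 48 h; a higher number here means a weaker inhibitor of growth, a lower number a stronger inhibitor of growth. Compound 1, `COc1cc(-c2cc(/C=C/C(=O)c3ccc(N)cc3)[nH]n2)cc(OC)c1OC`, gives 8320 nM in this assay, the lowest of the two numbers. Compound 2, `COc1ccc(-c2cc(/C=C/C(=O)c3ccc(OC)c(OC)c3)[nH]n2)cc1`, gives 17100 nM in this assay, a gap to compound 1 that lies beyond the usual scatter. The two differ in more than one place, so the gap cannot be assigned to any single change.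

Compound 3, `COc1cc(-c2cc(/C=C/C(=O)c3ccc(Cl)c(Cl)c3)[nH]n2)cc(OC)c1OC`, has not yet been measured. It differs from compound 1 in one place: 3,4-dichlorophenyl in place of 4-aminophenyl on a carbonyl carbon. Going by the values given here, no measured pair shows this change, so its effect is open. Because compound 1 sits at 8320 nM with the same core retained, a step of at most a modest size is expected in this assay, in either direction, and a result within the scatter of compound 1 would not be surprising; the expected step is a 1.2-fold higher number from compound 1 to compound 3 (0.08 log units; within the scatter). Compound 3 is accordingly estimated at 10000 nM in this assay, with a range from 3000 nM to 35000 nM.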

Compound 3, concentration for total growth inhibition: 18800 nM
For compound 3 the middle estimate is 1.9-fold (0.27 log units) below the measured one, within the range that was stated.
By their numbers in this assay, from the lowest: compound 1; then compounds 2 and 3 (each within the scatter of the next).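

On the shared core, the group on the carbonyl carbon is shown to affect the number in this assay, with 3,4-dichlorophenyl in place of 4-aminophenyl giving a 2.3-fold higher number from compound 1 to compound 3 (0.35 log units; beyond the scatter). This is the first single change that can be read among these compounds, and it favours 4-aminophenyl over 3,4-dichlorophenyl at this position. The entering group has no hydrogen-bond donor or acceptor and carries chlorine rather than nitrogen, but these differences arrive together, and no measurement here accounts for the step.

The compounds shown leave open whether the amine itself matters, since neither a hydroxyl, an acetamide nor an unsubstituted phenyl stands at this position. They also leave open whether a single chlorine would give a number closer to that of compound 1 or compound 3.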